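A Methyl on the Ring Carbon of Compound 1

A few compounds are considered here, and "the series" means these few. Any claim that something is new, unique, unknown or untested is made for them only; others in the source may bear on it.

Compound 1 `N#C[C@@H]1CCCN1C(=O)[C@@H]1C[C@H](C(=O)N2CCOCC2)CN1`: 73%
Compound 2 `CCCNC(=O)[C@@H]1CN[C@H](C(=O)N2CCC[C@H]2C#N)C1`: 59%

Among the measured compounds shown here, in an assay on the whole organism (plasma, strain Sprague-Dawley) for inhibition of Dipeptidyl peptidase 4 (Rattus norvegicus), with a stated time of 6 h, at a dose of 1 mg/kg by the oral route (on this read-out lower numbers stand for less inhibition and higher numbers for more inhibition at the one dose given (going by the name of the read-out)), compound 1 gives 73% and stands highest of the two numbers; the only comparison is the step of a number 14 percentage points lower from compound 1 to compound 2 (beyond the scatter). Compound 3 `C[C@@H]1N[C@H](C(=O)N2CCC[C@H]2C#N)C[C@@H]1C(=O)N1CCOCC1` differs from compound 1 by methyl in place of hydrogen on a saturated ring carbon. That one measured step swaps a group on a carbonyl carbon, not on a saturated ring carbon, so it does not bear on this change, and nothing measured tells how a methyl here acts. The expected step is therefore a number 5 percentage points lower from compound 1 to compound 3 (within the scatter), none beyond the scatter. Compound 3 is expected to give 68%, within 45% to 85%.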

Compound 3, a percentage reported as inhibition, in the whole organism at one dose (the size of the read-out at that dose, not a potency): 94%
Compound 3: the middle estimate sits 26 percentage points below what was measured, and the stated range ends below it.
By their numbers in this assay, from the lowest: compound 2; then compound 1; then compound 3.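

Methyl in place of hydrogen on the saturated ring carbon next to the ring nitrogen gives a number 21 percentage points higher from compound 1 to compound 3 (beyond the scatter) in this assay. Among the compounds shown here, the earlier compounds differed only in the group on a carbonyl carbon, so this is the first sign that this ring carbon can carry a group and that the change can raise the read-out. Nothing measured here explains the rise.

Going by these compounds, whether ethyl or a longer chain on this ring carbon would raise the number further remains open. So does whether the same methyl would act alike with the propylamino group of compound 2.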